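A second fluoro on the 4-fluorophenyl group

The source may hold more compounds than are shown below. What is called first, only, known or untested is meant among the compounds shown, and "the series" means these compounds.

In a functional assay on SNU-638 cells (Homo sapiens) for antiproliferative activity, read by sulforhodamine B assay, with a stated time of 72 h (on this read-out lower numbers stand for stronger inhibition and higher numbers for weaker inhibition), compound 1 (`COc1ncc(-c2ccc3ncnc(NCCN(C)C)c3c2)cc1NS(C)(=O)=O`) gives 410 nM, compound 2 (`COc1ncc(-c2ccc3ncnc(NCCN(C)C)c3c2)cc1NS(=O)(=O)c1ccc(F)cc1`) gives 1210 nM, and compound 3 (`CCCCS(=O)(=O)Nc1cc(-c2ccc3ncnc(NCc4ccncc4)c3c2)cnc1OC`) gives 6660 nM. Compound 2 therefore holds the middle of the three numbers, with compound 1 lower and compound 3 higher. Compound 3 differs from compound 2 in more than one place, so it does not isolate any single change.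

Compound 4 (`COc1ncc(-c2ccc3ncnc(NCCN(C)C)c3c2)cc1NS(=O)(=O)c1ccc(F)cc1F`) has not yet been measured. It turns the 4-fluorophenyl of compound 2 into 2,4-difluorophenyl: fluoro in place of hydrogen on an aromatic carbon. This puts fluoro in place of hydrogen on an aromatic carbon, ortho to a large group and meta to the existing fluoro group.

For the measured compounds named here, the one measured step that bears on this, a 3.0-fold higher number from compound 1 to compound 2 (0.47 log units; beyond the scatter), put 4-fluorophenyl in place of methyl on a sulfonyl sulfur and stayed modest, so a single exchange of hydrogen for fluoro is expected to move the number by less. Going by the values given here, no measured step shows a fluoro being added to this ring, so the data set no firm direction. The expected change is a 1.2-fold lower number from compound 2 to compound 4 (0.06 log units; within the scatter), which would not lie beyond the scatter. For compound 4 the estimated value in this assay is 1050 nM, with an expected range from 500 nM to 2300 nM.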

Compound 4, half-maximal inhibitory concentration: 620 nM
Compound 4: middle estimate off by 1.7-fold (0.23 log units), on the high side; the measured number falls inside the stated range.
By their numbers in this assay, from the lowest: compounds 1, 4 and 2 (each within the scatter of the next, the first and the last beyond it); then compound 3.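

In this assay, fluoro in place of hydrogen on an aromatic carbon, ortho to a large group and meta to a fluoro group, gives a 2.0-fold lower number from compound 2 to compound 4 (0.29 log units; within the scatter), so the second fluoro at this position produces no change that can be told from the scatter. The earlier step, a 3.0-fold higher number from compound 1 to compound 2 (0.47 log units; beyond the scatter), set the 4-fluorophenyl group apart from methyl beyond the scatter, whereas the 2,4-difluorophenyl group gives a 1.5-fold higher number from compound 1 to compound 4 (0.18 log units; within the scatter) and no such separation from methyl can be read. No measurement shown here offers an explanation for these steps.

Going by these compounds, it remains open whether a larger group in the same place, such as chloro, methoxy or trifluoromethyl, would also stay within the scatter of compound 2, or would instead move the number clearly in one direction. For the compounds shown here, it is also open whether adding a fluoro to the 4-fluorophenyl group would read the same with a different amine side chain, such as the one carried by compound 3, or with a longer chain in place of the dimethylaminoethyl group.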